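Pyridinyl for chlorophenyl on the shared core

The source may hold more compounds than are shown below. What is called first, only, known or untested is meant among the compounds shown, and "the series" means these compounds.

Measured compounds:
- compound 1 `COc1ccc(/C=C2/SC(N3CCC[C@H]3C(=O)Nc3ccc4ncnc(Nc5cccc(Cl)c5)c4c3)=NC2=O)cc1` — 31700 nM
- compound 2 `O=C1N=C(N2CCC[C@H]2C(=O)Nc2ccc3ncnc(Nc4cccc(Cl)c4)c3c2)S/C1=C/c1cccc(Cl)c1` — > 50000 nM
- compound 3 `Cc1cccc(/C=C2/SC(N3CCC[C@H]3C(=O)Nc3ccc4ncnc(Nc5cccc(Cl)c5)c4c3)=NC2=O)n1` — 8500 nM

Three analogues of the shared core have been read in a functional assay on A549 cells (Homo sapiens) for antiproliferative activity, read by MTT assay; on this read-out lower numbers stand for stronger inhibition and higher numbers for weaker inhibition. Compound 1 gives 31700 nM in this assay. For compound 2 only a limit is reported, > 50000 nM, so it sits at the limit of > 50000 nM in this assay, at which 1 of the 3 values shown sits, and no number is known for it. Compound 3 gives 8500 nM and stands apart from the others: a 3.7-fold lower number from compound 1 to compound 3 (0.57 log units; beyond the scatter), and an at least 5.8-fold lower number from compound 2 to compound 3 (0.76 log units; beyond the scatter). Between compounds 1 and 2 the change is an at least 1.5-fold higher number from compound 1 to compound 2 (0.19 log units; that floor lies within the scatter).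

The step under consideration leads from compound 2 to compound 4 `O=C1N=C(N2CCC[C@H]2C(=O)Nc2ccc3ncnc(Nc4cccc(Cl)c4)c3c2)S/C1=C/c1cccnc1`, with pyridin-3-yl in place of 3-chlorophenyl on a double-bonded chain carbon bound to a double-bonded ring carbon. Within the data shown here, the one measured step that bears on it directly is the one from compound 2 to compound 3, where a pyridinyl ring also replaced the 3-chlorophenyl and the number fell by at least a modest amount. The step from compound 1 to compound 3 points the same way. Compound 4 carries a pyridinyl ring without the methyl, so the effect is expected to be in the same direction but is uncertain in size. Compound 4 is therefore estimated at 18000 nM, within 6000 nM to 50000 nM, which is expected to mean an at least 2.7-fold lower number from compound 2 to compound 4 (0.44 log units; beyond the scatter).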

Compound 4, half-maximal inhibitory concentration: 10400 nM
Beside the measured number, compound 4's estimate is 1.7-fold (0.24 log units) above it, within the range that was stated.
By their numbers in this assay, from the lowest: compounds 3 and 4 (each within the scatter of the next); then compound 1. At a limit, above all of these: compound 2.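

In this assay, the gain seen with compound 3 does not depend on the methyl-bearing ring, since pyridin-3-yl on the double-bonded chain carbon also gives an at least 4.8-fold lower number from compound 2 to compound 4 (0.68 log units; beyond the scatter) and a 3.0-fold lower number from compound 1 to compound 4 (0.48 log units; beyond the scatter). The size of the first of these steps is only a floor, as compound 2 carries a limit and not a number: the limit of > 50000 nM in this assay, at which 1 of the 4 values shown sits. The two pyridine-bearing compounds cannot be told apart, with a 1.2-fold higher number from compound 3 to compound 4 (0.09 log units; within the scatter), so among the four compounds shown, both analogues with a ring nitrogen at this position give lower numbers than the two with a carbon-only aromatic ring, and neither the methyl group nor the difference between pyridin-3-yl and 6-methylpyridin-2-yl shows any effect of its own here.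

The compounds shown leave open whether pyridin-4-yl or an unsubstituted pyridin-2-yl would give a similar number, and whether a five-membered ring such as thiazole or imidazole would serve as well. They also leave open whether a pyridine ring carrying an amine or a carboxylic acid would move the number further, and they do not say why the ring nitrogen matters in these cells.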